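From Methoxy to Nitro on the Terminal Aryl Ring

The source may hold more compounds than are shown below. What is called first, only, known or untested is meant among the compounds shown, and "the series" means these compounds.

In a functional assay on HEK293 cells for agonist activity at Free fatty acid receptor 1 (Homo sapiens), read by fluorescence and calcium flux (on this read-out higher numbers stand for an effect only at larger amounts of compound and lower numbers for an effect already at smaller amounts), compound 1 `CC#CC(CC(=O)O)c1ccc(OCc2ccc(C(=O)N3CCN(c4ccccc4)CC3)s2)cc1` gives 72 nM. Compound 2 `CC#CC(CC(=O)O)c1ccc(OCc2ccc(C(=O)N3CCN(c4cccnc4)CC3)s2)cc1` gives 1140 nM, and compound 3 `CC#CC(CC(=O)O)c1ccc(OCc2ccc(C(=O)N3CCN(c4ccc(OC)cc4)CC3)s2)cc1` gives 289 nM. Compound 3 therefore holds the second highest of the three numbers: the nearer neighbour is shown by a 3.9-fold lower number from compound 2 to compound 3 (0.60 log units; beyond the scatter), the farther by a 4.0-fold higher number from compound 1 to compound 3 (0.60 log units; beyond the scatter). Compound 4 `CC#CC(CC(=O)O)c1ccc(OCc2ccc(C(=O)N3CCN(c4cccc([N+](=O)[O-])c4)CC3)s2)cc1` differs from compound 3 by 3-nitrophenyl in place of 4-methoxyphenyl on an amine nitrogen in a ring. For the measured compounds named here, no measured step exchanges one substituted phenyl for another, yet both departures from the plain phenyl raised the number, a 16-fold higher number from compound 1 to compound 2 (1.20 log units; beyond the scatter) and a 4.0-fold higher number from compound 1 to compound 3 (0.60 log units; beyond the scatter), so an expected step of a 1.6-fold higher number from compound 3 to compound 4 (0.19 log units; within the scatter) in this assay, toward a higher number but modest, seems reasonable. Compound 4 is estimated at 450 nM, between 130 nM and 1600 nM.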

Compound 4, half-maximal effective concentration: 187 nM
The estimate for compound 4 lay 2.4-fold (0.38 log units) above the measured number; measured number inside the range.
By their numbers in this assay, from the lowest: compound 1; then compounds 4 and 3 (each within the scatter of the next); then compound 2.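

In this assay, 3-nitrophenyl on the amine nitrogen in the ring cannot be told apart from 4-methoxyphenyl (a 1.5-fold lower number from compound 3 to compound 4 (0.19 log units; within the scatter)), so two quite different substituted phenyls read alike at this position. Nitro in place of hydrogen on the plain phenyl still gives a higher number (a 2.6-fold higher number from compound 1 to compound 4 (0.41 log units; beyond the scatter)), yet the nitro compound lies well under the pyridin-3-yl compound (a 6.1-fold lower number from compound 2 to compound 4 (0.79 log units; beyond the scatter)). No supporting measurement accounts for these differences. As far as these compounds go, how a chlorophenyl or an aminophenyl on the same nitrogen would read remains open, as does whether nitro and methoxy would keep these numbers elsewhere on the phenyl.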